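This account rests on a few compounds, and the source may have more. Where it says the series, first, only, none or still open, it means among the compounds named here.

Measured so far:
- compound 1 `CCCOc1ccc2oc(/C=C/[S+](C)[O-])cc(=O)c2c1`: in a functional assay on A549 cells (Homo sapiens) for cytotoxicity, with a stated time of 48 h (on this read-out higher numbers stand for weaker inhibition and lower numbers for stronger inhibition), compound 1 gives 1100 nM
- compound 2 `Cc1ccc2oc(/C=C/[S+](C)[O-])cc(=O)c2c1`: in this assay compound 2 gives 1700 nM
- compound 3 `CCOc1ccc2oc(/C=C/[S+](C)[O-])cc(=O)c2c1`: in this assay compound 3 gives 1500 nM

Compound 3 sits second highest of the three numbers, with a 1.1-fold lower number from compound 2 to compound 3 (0.05 log units; within the scatter) and a 1.4-fold higher number from compound 1 to compound 3 (0.13 log units; within the scatter) both inside the scatter. Compound 4 `C[S+]([O-])/C=C/c1cc(=O)c2cc(C#N)ccc2o1` differs from compound 3 by cyano in place of ethoxy on an aromatic carbon. Among the compounds with values here, no measured step exchanges an alkoxy group for cyano; the steps that touch this aromatic carbon, a 1.5-fold higher number from compound 1 to compound 2 (0.19 log units; within the scatter) and a 1.1-fold lower number from compound 2 to compound 3 (0.05 log units; within the scatter), were all within the scatter, so the position has so far tolerated change without a shift in this assay. Cyano is untested, so the expectation is a step of no change at the digits printed from compound 3 to compound 4 (within the scatter), none beyond the scatter. Compound 4 is estimated at 1500 nM, range 700 nM to 3500 nM.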

Compound 4, half-maximal inhibitory concentration: > 10000 nM
Compound 4 was reported as a limit; the forecaster's own chance of this, stated with the estimate: 5%; middle value at least 6.6-fold (0.82 log units) away from the limit.
By their numbers in this assay, from the lowest: compounds 1, 3 and 2 (each within the scatter of the next). At a limit, above all of these: compound 4.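

In this assay, this aromatic carbon is no longer indifferent to its substituent: methyl, ethoxy and propoxy lay within the scatter of one another, whereas cyano gives an at least 6.6-fold higher number from compound 3 to compound 4 (0.82 log units; beyond the scatter), an at least 5.8-fold higher number from compound 2 to compound 4 (0.76 log units; beyond the scatter) and an at least 9.0-fold higher number from compound 1 to compound 4 (0.95 log units; beyond the scatter). Compound 4 is reported only as a limit: the limit of > 10000 nM in this assay, at which 1 of the 4 values shown sits. As far as these compounds go, the full size of the three steps therefore remains unknown.

The compounds shown leave open whether this shift is specific to cyano or would recur with an amine or a carboxylic acid on the same carbon.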